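The source may report more compounds than this note shows. Statements on the series, on what has been measured and on what is new or still open speak of the compounds shown alone.

Compound 2 `Fc1ccc2nc(-c3cccnc3)n(C3CC3)c2c1` gives 4 nM in an assay on V79 cells for inhibition of cytochrome P450 11B2, mitochondrial (Homo sapiens), read by HTRF, with a stated time of 1 h (a lower number here means a stronger inhibitor, a higher number a weaker inhibitor), the higher of the two numbers shown, though the gap to compound 1 stays within the scatter. Compound 1 `Fc1cc2nc(-c3cccnc3)n(C3CC3)c2cc1F` gives 2.1 nM in this assay; the step of a 1.9-fold higher number from compound 1 to compound 2 (0.28 log units; within the scatter). Compound 3 `Fc1ccc2nc(-c3cccnc3)[nH]c2c1` gives only a limit in this assay, > 10000 nM. The step of an at least 2500-fold higher number from compound 2 to compound 3 (3.39 log units; beyond the scatter). Compound 4 `Clc1ccc2nc(-c3cccnc3)n(C3CC3)c2c1` differs from compound 2 by chloro in place of fluoro on an aromatic carbon. Within the data shown here, of the measured steps, only that from compound 1 to compound 2 concerns a halogen on the six-membered aromatic ring of carbon only, and it stayed within the scatter; the large step from compound 2 to compound 3 concerns the substituent on the aromatic nitrogen and does not bear on this change. A step no larger than the scatter is therefore expected in this assay, a 1.3-fold higher number from compound 2 to compound 4 (0.10 log units; within the scatter). Compound 4 is expected to give 5 nM, between 2 nM and 15 nM.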

Compound 4, half-maximal inhibitory concentration: 2.2 nM
Compound 4: the middle estimate sits 2.3-fold (0.36 log units) above what was measured; measured number inside the range.
By their numbers in this assay, from the lowest: compounds 1, 4 and 2 (each within the scatter of the next). At a limit, above all of these: compound 3.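

Chloro in place of fluoro on this aromatic carbon gives a 1.8-fold lower number from compound 2 to compound 4 (0.26 log units; within the scatter) in this assay, so the two halogens are not told apart at this position. The earlier halogen step exchanged hydrogen for fluoro, whereas this one shows that a chlorine is accommodated here with no change beyond the scatter. Nothing measured here bears on this step.

Open, as far as these compounds go, is how groups other than halogens, such as an amine, a methoxy group or a carboxylic acid, behave on this carbon. Also open, from the compounds shown here alone, is how a longer chain in place of cyclopropyl on the aromatic nitrogen compares.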